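This account rests on a few compounds, and the source may have more. Where it says the series, first, only, none or still open, it means among the compounds named here.

Compound 1 `CC(C)(C)Cc1c(-c2ccncc2)sc(N)c1C(=O)c1ccc(Cl)cc1` was examined in an assay on CHO cells for displacement of a labelled ligand from adenosine receptor A1 (Homo sapiens), read by scintillation counting, tested at 10 uM (a higher number here means more inhibition at the concentration tested (going by the name of the read-out), a lower number less inhibition), where compound 1 gives 1%. A second compound, compound 2 `CC(C)(C)Cc1csc(N)c1C(=O)c1ccc(Cl)c(Cl)c1`, gives 1% in this assay; compound 1 stands level with compound 2 at the digits reported, and nothing in these two numbers separates them beyond the usual scatter. Compound 3 `Cc1noc(C)c1-c1sc(N)c(C(=O)c2ccc(Cl)cc2)c1CC(C)(C)C` has not yet been measured in this assay. It differs from compound 1 in one place: 3,5-dimethyl-1,2-oxazol-4-yl in place of pyridin-4-yl on an aromatic carbon. For the measured compounds named here, no step between measured compounds bears on this change, and compound 1 with 1% sits near the bottom of what the read-out can show, so the account rests on that single value. The step of a number 2 percentage points higher from compound 1 to compound 3 (within the scatter) is expected to be no larger than the scatter in either direction. The estimate for compound 3 is 3%, within a range from -8% to 15%.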

Compound 3, a percentage reported as inhibition, at one concentration (the size of the read-out at that concentration, not a potency): 1%
For compound 3 the middle estimate is 2 percentage points above the measured one, and the stated range covers the measured number.
By their numbers in this assay, from the lowest: compounds 1, 2 and 3 (each within the scatter of the next).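

In this assay, for the compounds shown here, replacing pyridin-4-yl with 3,5-dimethyl-1,2-oxazol-4-yl on the aromatic carbon next to the ring sulfur gives no change at the digits printed from compound 1 to compound 3 (within the scatter), the only step here that bears on this position. Going by these compounds alone, a six-membered aromatic ring with 1 hetero atom and a five-membered aromatic ring with 2 hetero atoms therefore cannot be told apart here, but with compound 3 at 1%, still near the bottom of what the read-out can show, the step shows only that neither group lifts the number from there. Nothing available explains this result.

Going by these compounds, whether an aliphatic amine or a carboxylic acid on this carbon would give a higher number remains open. So does whether pyridin-4-yl and 3,5-dimethyl-1,2-oxazol-4-yl would differ on a compound reading well above the bottom of the scale.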